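The compounds below may be only part of what the source reports. "The series", "measured", "known", "first", "only" and "open" are said of these compounds alone.

Compound 1 `CCCc1nc(CC)c(C(=O)OCC(=O)c2ccccc2)n1Cc1ccc(-c2ccccc2S(=O)(=O)NC(=O)OCCC(C)C)cc1F`: 2 nM
Compound 2 `CCCc1nc(CC)c(C(=O)OCc2ccccc2OC)n1Cc1ccc(-c2ccccc2S(=O)(=O)NC(=O)OCCC(C)C)cc1F`: 1 nM

In an assay on isolated protein for binding affinity to Type-2 angiotensin II receptor (Homo sapiens) (a higher number here means a weaker inhibitor, a lower number a stronger inhibitor), compound 2 and compound 1 lie within the scatter of each other, a 2.0-fold lower number from compound 1 to compound 2 (0.30 log units; within the scatter), so neither can be called the stronger binder. Compound 3 `CCCc1nc(CC)c(C(=O)OCc2ccccc2S(=O)(=O)c2ccccc2)n1Cc1ccc(-c2ccccc2S(=O)(=O)NC(=O)OCCC(C)C)cc1F` differs from compound 2 by phenylsulfonyl in place of methoxy on an aromatic carbon. Among the compounds with values here, the only measured step concerns another part of the molecule and stayed within the scatter, so no measured step bears directly on this change, and no shift beyond the scatter is expected in this assay. Compound 3 is therefore expected to give about 2 nM, within 0.5 nM to 8 nM, an estimated step of a 2.0-fold higher number from compound 2 to compound 3 (0.30 log units; within the scatter).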

Compound 3, half-maximal inhibitory concentration: 5 nM
Compound 3: middle estimate off by 2.5-fold (0.40 log units), on the low side; low and high end bracket the measured number.
By their numbers in this assay, from the lowest: compounds 2 and 1 (each within the scatter of the next); then compound 3.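

In this assay, within the data shown here, phenylsulfonyl in place of methoxy on this aromatic carbon gives a 5.0-fold higher number from compound 2 to compound 3 (0.70 log units; beyond the scatter), the first step in this set beyond the scatter, though only a modest one. This position therefore responds to the group placed on it, yet compound 3 still reads 5 nM with nine heavy atoms and an added aromatic ring in the new group. No measurement here explains the shift. As far as these compounds go, whether a plain phenyl or a methylsulfonyl group would read closer to compound 2 or to compound 3 stays open.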